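Compound 3 to compound 4: changing the carbonyl substituent

The compounds below may be only part of what the source reports. "The series", "measured", "known", "first", "only" and "open" are said of these compounds alone.

In a functional assay on A549 cells (Homo sapiens) for inhibition, read by MTT assay, with a stated time of 72 h (on this read-out lower numbers stand for stronger inhibition and higher numbers for weaker inhibition), compound 1 (`Cc1ccc(NC(=O)CCC(=O)OCCCCCCSc2ccc([N+](=O)[O-])c3nonc23)cc1`) gives 5240 nM and compound 2 (`COc1ccc(NC(=O)CCC(=O)OCCCCCCSc2ccc([N+](=O)[O-])c3nonc23)cc1`) gives 6480 nM, while compound 3 (`O=C(CCC(=O)OCCCCCCSc1ccc([N+](=O)[O-])c2nonc12)Nc1ccc(C(F)(F)F)cc1`) gives 4020 nM on the same read-out. Compound 3 thus sits within the scatter of both others: the steps (a 1.3-fold lower number from compound 1 to compound 3 (0.12 log units; within the scatter)) and (a 1.6-fold lower number from compound 2 to compound 3 (0.21 log units; within the scatter)), like the step (a 1.2-fold higher number from compound 1 to compound 2 (0.09 log units; within the scatter)), all stay within the scatter. Compound 4 (`O=C(CCC(=O)N1CCOCC1)OCCCCCCSc1ccc([N+](=O)[O-])c2nonc12`) has morpholin-4-yl in place of (4-(trifluoromethyl)phenyl)amino on a carbonyl carbon. The measured steps only exchange a group on an aromatic carbon, so none tests this change directly. In this assay a small rise is expected, with no step beyond the scatter: the estimated step is (a 1.5-fold higher number from compound 3 to compound 4 (0.17 log units; within the scatter)). Compound 4 is expected at 6000 nM with an estimated range (2500 nM to 15000 nM).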

Compound 4, half-maximal inhibitory concentration: 1670 nM
Compound 4: middle estimate off by 3.6-fold (0.56 log units), on the high side, outside the stated range (below it).
By their numbers in this assay, from the lowest: compound 4; then compounds 3, 1 and 2 (each within the scatter of the next).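

In this assay, the carbonyl substituent proves a more sensitive position than the group on the aromatic carbon. Morpholin-4-yl in place of the three anilide amino groups gives a 2.4-fold lower number from compound 3 to compound 4 (0.38 log units; beyond the scatter), a 3.1-fold lower number from compound 1 to compound 4 (0.50 log units; beyond the scatter) and a 3.9-fold lower number from compound 2 to compound 4 (0.59 log units; beyond the scatter), all beyond the scatter, whereas the exchanges on the aromatic carbon all stayed within it. No evidence at hand accounts for this gain.

Among these compounds, the single exchange removes the aromatic ring and the amide hydrogen and adds the ring oxygen together, so their separate contributions remain open. Piperidin-1-yl or dimethylamino on the same carbonyl carbon would begin to separate them.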